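Cinnamoyl amide replacing benzofuranoyl on a threonine-tetradecylamide scaffold

This account rests on a few compounds, and the source may have more. Where it says the series, first, only, none or still open, it means among the compounds named here.

Measured compounds in a functional assay on SiHa cells (Homo sapiens) for cytotoxicity, read by MTT assay, with a stated time of 48 h; on this read-out lower numbers stand for stronger inhibition and higher numbers for weaker inhibition:
compound 1 `CCCCCCCCCCCCCCNC(=O)[C@@H](NC(=O)c1ccccc1)[C@@H](C)O`: > 200000 nM, a limit of the assay.
compound 2 `CCCCCCCCCCCCCCNC(=O)[C@@H](NC(=O)c1ccco1)[C@@H](C)O`: 127000 nM
compound 3 `CCCCCCCCCCCCCCNC(=O)[C@@H](NC(=O)c1cc2ccccc2o1)[C@@H](C)O`: 14200 nM

Compound 3 gives the lowest number of the values shown; its nearest neighbour is compound 2, with an 8.9-fold lower number from compound 2 to compound 3 (0.95 log units; beyond the scatter). Compound 4 `CCCCCCCCCCCCCCNC(=O)[C@@H](NC(=O)/C=C/c1ccccc1)[C@@H](C)O` differs from compound 3 in one place: 2-phenylethenyl in place of 1-benzofuran-2-yl on a carbonyl carbon. Going by the values given here, no measured step exchanges the benzofuranyl group for an open-chain group, so the steps that bear on it are indirect: an at least 14-fold lower number from compound 1 to compound 3 (1.14 log units; beyond the scatter) and an at least 1.5-fold lower number from compound 1 to compound 2 (0.19 log units; that floor lies within the scatter), both showing that the smaller aromatic groups on this carbonyl carbon give higher numbers than the benzofuranyl group. Since the entering group shares the six-membered carbon ring of compound 1 but is extended by the double bond, compound 4 is expected to fall between compound 1 and compound 3, with a 3.5-fold higher number from compound 3 to compound 4 (0.55 log units; beyond the scatter) as the expected step. Compound 4 is therefore estimated at 50000 nM, within 15000 nM to 200000 nM.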

Compound 4, half-maximal inhibitory concentration: 35800 nM
For compound 4 the middle estimate is 1.4-fold (0.15 log units) above the measured one, within the range that was stated.
By their numbers in this assay, from the lowest: compound 3; then compound 4; then compound 2. At a limit, above all of these: compound 1.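

The position does not need a fused ring or a ring oxygen to give a low number: the 2-phenylethenyl group, with no hydrogen-bond acceptor, still gives a 3.5-fold lower number from compound 2 to compound 4 (0.55 log units; beyond the scatter), although 1-benzofuran-2-yl stays ahead, with a 2.5-fold higher number from compound 3 to compound 4 (0.40 log units; beyond the scatter). Extending phenyl by a double bond also lowers the number, with an at least 5.5-fold lower number from compound 1 to compound 4 (0.74 log units; beyond the scatter). That step is only a floor, resting on the limit of compound 1: the limit of > 200000 nM in this assay, at which 1 of the 4 values shown sits.

On these data alone, what a saturated 2-phenylethyl group or a methoxy-bearing 2-phenylethenyl group would give on this carbonyl carbon stays open. So does whether this order holds with a chain shorter than tetradecyl.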